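Lengthening the Amine Chain from Compound 2 to Compound 3

The compounds below may be only part of what the source reports. "The series", "measured", "known", "first", "only" and "open" are said of these compounds alone.

Of the compounds shown here, two have been measured in a functional assay on brain for inhibition of Norepinephrine transporter (Rattus norvegicus); a lower number here means a stronger inhibitor, a higher number a weaker inhibitor. Compound 1, `CN(C)C/C=C(/c1ccc(Cl)cc1)c1cccnc1`, gives 10000 nM. Compound 2, `CCNC/C=C(/c1ccc(Br)cc1)c1cccnc1`, gives 26000 nM. Compound 2 thus stands with the highest of the two numbers; its nearest neighbour is compound 1, whose number is lower by a margin beyond the usual scatter. Among the measured compounds shown here, no single-point step between these two measured compounds exists, since they differ in more than one place, and what they show is only that the two numbers lie apart.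

Compound 3, `CCCNC/C=C(/c1ccc(Br)cc1)c1cccnc1`, has not yet been measured in this assay. It differs from compound 2 by methyl in place of hydrogen on a saturated chain carbon, two bonds along the chain from an amine nitrogen. For the measured compounds named here, no measured pair in this set isolates that change, so no step can be quoted for it. The step in this assay from compound 2 to compound 3 is expected to be small, in no particular direction, and probably within the scatter, which a 1.0-fold lower number from compound 2 to compound 3 (0.02 log units; within the scatter) expresses. Compound 3 is therefore estimated at 25000 nM, with a range from 8000 nM to 70000 nM.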

Compound 3, half-maximal inhibitory concentration: > 24000 nM
Compound 3 was reported as a limit; the forecaster's own chance of this, stated with the estimate: 15%; the middle value does not contradict the limit.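

In this assay compound 3 gives > 24000 nM, which is a limit and not a number. Among the compounds shown here, no step from compound 2 to compound 3 can be read, and the result rests on one entry: the limit of > 24000 nM in this assay, at which 1 of the 3 values shown sits. The compounds shown leave open what the change from ethylamino to propylamino does in this assay.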